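Swapping the cyclopropyl for 2-chlorophenyl on the triazole arm

The source may report more compounds than this note shows. Statements on the series, on what has been measured and on what is new or still open speak of the compounds shown alone.

The study measures inhibition in a functional assay on RAW264.7 cells (Mus musculus) for inhibition, read by Griess assay, with stated times of 2 h and 24 h; on this read-out higher numbers stand for weaker inhibition and lower numbers for stronger inhibition. Of the compounds shown here, two have numbers so far. Compound 1, `COc1ccc([C@@H]2C/C(=N\O)c3c(O)cc(OCc4cn(CC5CC5)nn4)cc3O2)cc1O`, gives 6320 nM in this assay. Compound 2, `COc1ccc([C@@H]2CC(=O)c3c(O)cc(OCc4cn(C5CCCC5)nn4)cc3O2)cc1O`, gives 10500 nM in this assay. Compound 1 holds the lowest of these two numbers, but its distance to compound 2 lies within the scatter, so the two cannot be placed in order.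

Compound 3, `COc1ccc([C@@H]2C/C(=N\O)c3c(O)cc(OCc4cn(Cc5ccccc5Cl)nn4)cc3O2)cc1O`, has not been measured. It differs from compound 1 in one place: 2-chlorophenyl in place of cyclopropyl on a saturated chain carbon bound to an aromatic nitrogen. Within the data shown here, no measured pair shows this change, so nothing here tells how large its effect is. The step from a 1.3-fold lower number from compound 1 to compound 3 (0.10 log units; within the scatter) is expected to be small, on either side of the scatter, with perhaps a slight lean toward a lower number. Compound 3 is therefore estimated at 5000 nM in this assay, within a range from 1500 nM to 16000 nM.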

Compound 3, half-maximal inhibitory concentration: 13400 nM
For compound 3 the middle estimate is 2.7-fold (0.43 log units) below the measured one, and the stated range covers the measured number.
By their numbers in this assay, from the lowest: compounds 1, 2 and 3 (each within the scatter of the next, the first and the last beyond it).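

In this assay, among these compounds, this is the first measured change on the saturated chain carbon bound to an aromatic nitrogen, and it gives a 2.1-fold higher number from compound 1 to compound 3 (0.33 log units; beyond the scatter), a modest step that shows the position is not indifferent to what it carries. On the core of compound 1, replacing cyclopropyl with 2-chlorophenyl goes with weaker inhibition, although this single pair cannot separate the contribution of the aromatic ring from that of the chlorine. No supporting data on these compounds account for the step.

From the compounds shown here alone, it remains open whether a plain phenyl without the chlorine would keep the number of compound 1 or follow that of compound 3. Going by these compounds, how an amine or a longer alkyl chain at this position would read also remains unknown.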